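Biaryl acid imidazoles: cyclohexyl to 3-methoxybenzyl

The source may hold more compounds than are shown below. What is called first, only, known or untested is meant among the compounds shown, and "the series" means these compounds.

Measured compounds:
Compound 1, `CCCCc1cnc(Cc2ccc(-c3ccccc3C(=O)O)cc2)[nH]1`: > 10000 nM
Compound 2, `CCCCc1cnc(C(CCC)Cc2ccc(-c3ccccc3C(=O)O)cc2)[nH]1`: 165 nM
Compound 3, `O=C(O)c1ccccc1-c1ccc(CCc2ncc(C3CCCCC3)[nH]2)cc1`: 14.7 nM

In an in vitro functional assay on cells for agonist activity at Bombesin receptor subtype-3 (Mus musculus), read by luminescence and calcium flux (a higher number here means that more compound is needed for the effect, a lower number that less compound is needed), compound 1 reaches only a limit, > 10000 nM, and gives no number; this is the limit of > 10000 nM in this assay, at which 1 of the 3 values shown sits. Compound 2 gives a number in this assay, 165 nM. Compound 3 gives 14.7 nM in this assay, the lowest of the two numbers shown, and its gap to compound 2 lies beyond the scatter. Among the measured compounds shown here, no two of the measured compounds differ in one place only, so no single measured step separates them.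

Compound 4, `COc1cccc(Cc2cnc(CCc3ccc(-c4ccccc4C(=O)O)cc3)[nH]2)c1`, has not been measured. It differs from compound 3 in one place: 3-methoxybenzyl in place of cyclohexyl on an aromatic carbon. The shared core and the biaryl acid are kept. For the measured compounds named here, no measured step bears on an aryl group at this position; the only comparisons are between compounds that differ in more than one place.

For compound 4 the expected step of a 2.7-fold higher number from compound 3 to compound 4 (0.43 log units; beyond the scatter) in this assay is a small loss, within or just beyond the scatter. Compound 4 is estimated at 40 nM, with a range from 8 nM to 250 nM.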

Compound 4, half-maximal effective concentration: 79 nM
Compound 4: middle estimate off by 2.0-fold (0.30 log units), on the low side; measured number inside the range.
By their numbers in this assay, from the lowest: compound 3; then compound 4; then compound 2. At a limit, above all of these: compound 1.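

Among the compounds shown here, the first one-place comparison concerns this position: in this assay, 3-methoxybenzyl in place of cyclohexyl on the aromatic carbon gives a 5.4-fold higher number from compound 3 to compound 4 (0.73 log units; beyond the scatter). The step is modest, so this position can carry a six-membered aromatic ring with a methoxy group as well as a non-aromatic ring of carbon only, although cyclohexyl gives the lower number of the two. The data shown give no measured property that accounts for the step.

For the compounds shown here, the single change swaps the ring type, the methoxy group and the added carbon link together, so a plain benzyl or phenyl group would be needed to separate their contributions. On these data alone, whether a smaller ring such as cyclopentyl, or a benzyl group carrying an amine, fits this position also remains open.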